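The compounds below may be only part of what the source reports. "The series", "measured", "known", "first", "only" and "open" are said of these compounds alone.

Going by the values given here, in a functional assay on MCF7 cells (Homo sapiens) for inhibition, read by MTT assay, with a stated time of 72 h (on this read-out lower numbers stand for stronger inhibition and higher numbers for weaker inhibition), three compounds have numbers so far. Compound 1 (`COc1ccc(-c2nnc(SCCCN3CCN(c4nc5ccccc5o4)CC3)o2)cc1`) gives 52800 nM, compound 2 (`O=C(NCc1nnc(SCCCN2CCN(c3nc4ccccc4o3)CC2)o1)c1ccccc1`) gives 52700 nM, and compound 3 (`COc1ccc(-c2nnc(SCCCN3CCN(c4nc5ccccc5s4)CC3)o2)cc1`) gives 171000 nM. That last number is the highest of the three, and it lies beyond the scatter from both of the others. Compound 4 (`Cc1ccc(-c2nnc(SCCCN3CCN(c4nc5ccccc5s4)CC3)o2)cc1`) has not yet been measured. It differs from compound 3 in one place, with methyl in place of methoxy on an aromatic carbon, para to a large group, so that 4-methoxyphenyl becomes 4-methylphenyl (methyl in place of methoxy on an aromatic carbon). Among the compounds with values here, no measured pair makes this exact change. The closest evidence is a 1.0-fold lower number from compound 1 to compound 2 (0.00 log units; within the scatter), a step that puts benzamidomethyl in place of 4-methoxyphenyl at the same site and lies within the scatter. That step was taken with 1,3-benzoxazol-2-yl on the amine nitrogen, whereas compound 4 carries 1,3-benzothiazol-2-yl. The other measured step, a 3.2-fold higher number from compound 1 to compound 3 (0.51 log units; beyond the scatter), is that modest swap of those two groups, and it bears on the change at the aromatic carbon only as background. The expected outcome is therefore no step beyond the scatter. The estimated change is a 1.1-fold lower number from compound 3 to compound 4 (0.06 log units; within the scatter). Compound 4 is expected at 150000 nM, with an estimated range of 60000 nM to 350000 nM.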

Compound 4, half-maximal inhibitory concentration: 107000 nM
Compound 4: the middle estimate sits 1.4-fold (0.15 log units) above what was measured, within the range that was stated.
By their numbers in this assay, from the lowest: compounds 2 and 1 (each within the scatter of the next); then compounds 4 and 3 (each within the scatter of the next).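

Methyl in place of methoxy on an aromatic carbon, para to a large group, now has a direct reading: in this assay the change gives a 1.6-fold lower number from compound 3 to compound 4 (0.20 log units; within the scatter) and stays within the scatter, even though methoxy's one hydrogen-bond acceptor leaves with it. Going by these compounds alone, until now the only step at this site was a 1.0-fold lower number from compound 1 to compound 2 (0.00 log units; within the scatter) with 1,3-benzoxazol-2-yl on the amine nitrogen, so the new step is the first at this site with 1,3-benzothiazol-2-yl there, and it also leaves the number within the scatter. Across these two pairs, neither the large replacement nor the small one separates its compounds, whereas the one step beyond the scatter among the compounds shown lies at the amine nitrogen, and nothing at hand gives a reason for the size of the new step.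

On these data alone, whether an amine or a carboxylic acid on this aromatic carbon would move the number beyond the scatter remains open. Also open, as far as these compounds go, is whether methyl in place of methoxy reads the same with 1,3-benzoxazol-2-yl on the amine nitrogen.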